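The source may hold more compounds than are shown below. What is called first, only, known or untested is meant among the compounds shown, and "the series" means these compounds.

In a functional assay on PC-3 cells (Homo sapiens) for inhibition, read by MTT assay, with a stated time of 72 h (on this read-out lower numbers stand for stronger inhibition and higher numbers for weaker inhibition), compound 3 `Cc1csc(Sc2cc(C(F)(F)F)nc(SCc3ccc(C(F)(F)F)cc3)n2)n1` gives 12000 nM. That is the lower of the two actual numbers in this small set, and the gap to compound 1 `CC(C)(C)OC(=O)N1CCN(c2cc(C(F)(F)F)nc(SCc3ccc(C(F)(F)F)cc3)n2)CC1`, which gives 40600 nM, lies beyond the scatter. Compound 2 `FC(F)(F)c1ccc(CSc2nc(N3CCN(c4ccccn4)CC3)cc(C(F)(F)F)n2)cc1` reads > 50000 nM, which is a limit of the assay and not a number.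

Compound 4 `Cc1nnc(Sc2cc(C(F)(F)F)nc(SCc3ccc(C(F)(F)F)cc3)n2)s1` differs from compound 3 in one place, on a sulfur whose other neighbour is an aromatic carbon: 5-methyl-1,3,4-thiadiazol-2-yl stands in place of 4-methyl-1,3-thiazol-2-yl (5-methyl-1,3,4-thiadiazol-2-yl in place of 4-methyl-1,3-thiazol-2-yl on a sulfur).

Going by the values given here, the only measured step, an at least 1.2-fold higher number from compound 1 to compound 2 (0.09 log units; that floor lies within the scatter), is a swap on an amine nitrogen in a ring, not on this sulfur, and its floor lies within the scatter. It therefore gives no size or direction for the new change. No step beyond the scatter is expected in this assay, so the estimate stays close to the value of compound 3. The expected change is small: a 1.2-fold higher number from compound 3 to compound 4 (0.07 log units; within the scatter). For compound 4, the estimated value is 14000 nM, with an expected range of 5000 nM to 40000 nM.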

Compound 4, half-maximal inhibitory concentration: > 50000 nM
Compound 4: a limit, no number (the forecaster's own chance of this, stated with the estimate: 10%); at least 3.5-fold (0.55 log units) between middle value and limit.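

Going by these compounds alone, on this sulfur, 5-methyl-1,3,4-thiadiazol-2-yl in place of 4-methyl-1,3-thiazol-2-yl gives an at least 4.1-fold higher number from compound 3 to compound 4 (0.61 log units; beyond the scatter) in this assay and is the first step in this set that lies beyond the scatter. Both groups are five-membered aromatic rings with no net charge, and the entering ring holds 3 hetero atoms where the leaving ring holds 2, so even this small exchange on this sulfur is enough to shift the read-out. The reading of compound 4 is a limit and not a number, and it is a limit shared within this small set: the limit of > 50000 nM in this assay, at which 2 of the 4 values shown sit.

Still open, as far as these compounds go, is how a plain phenyl ring, a pyridine ring or a simple amine would read at this place on the core. Within the data shown here, compound 3 is the only compound with a ring on this sulfur that gives an actual number, so this single step describes this pair alone and sets no general rule.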